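Moving one fluorine on the benzyl group of compound 3

This account rests on a few compounds, and the source may have more. Where it says the series, first, only, none or still open, it means among the compounds named here.

compound 1 `N#C/C(=C\c1ccccc1OS(=O)(=O)c1ccccc1[N+](=O)[O-])C(=O)Nc1nnc(Cc2ccc(F)cc2)s1` gives 61%
compound 2 `N#C/C(=C\c1ccccc1OS(=O)(=O)c1ccc(Cl)cc1)C(=O)Nc1nnc(Cc2ccc(F)cc2)s1` gives 68%
compound 3 `N#C/C(=C\c1ccccc1OS(=O)(=O)c1ccc(F)cc1)C(=O)Nc1nnc(Cc2ccc(F)cc2)s1` gives 59%

In a functional assay on RS4-11 cells (Homo sapiens) for inhibition, read by CCK-8 assay, with a stated time of 48 h, tested at 20 uM (on this read-out lower numbers stand for less inhibition of growth and higher numbers for more inhibition of growth at the one concentration tested), compound 3 gives 59% and does not stand apart from the other two compounds. Both a number 2 percentage points lower from compound 1 to compound 3 (within the scatter) and a number 9 percentage points lower from compound 2 to compound 3 (within the scatter) stay inside the usual scatter of repeat measurements, and a number 7 percentage points higher from compound 1 to compound 2 (within the scatter) stays there too.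

Compound 4 `N#C/C(=C\c1ccccc1OS(=O)(=O)c1ccc(F)cc1)C(=O)Nc1nnc(Cc2cccc(F)c2)s1` differs from compound 3 at a single place: 3-fluorophenyl in place of 4-fluorophenyl on a saturated chain carbon bound to an aromatic carbon (in words, 3-fluorophenyl in place of 4-fluorophenyl on a saturated chain carbon bound to an aromatic carbon).

Going by the values given here, none of the measured steps touches this group. All three swap the group on the sulfonyl sulfur, so they bear on the new change only indirectly, and the data hold no direct reading of it. The nearest guide is the single-atom swap a number 9 percentage points lower from compound 2 to compound 3 (within the scatter) in the same series.

The expected outcome is a number 1 percentage points higher from compound 3 to compound 4 (within the scatter) with no direction favoured. For compound 4 the estimated value is 60% within an expected range of 46% to 74% as estimated here.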

Compound 4, percent growth inhibition at one concentration: 72%
Estimate against measurement, compound 4: 12 percentage points below; the range from low to high includes it.
By their numbers in this assay, from the lowest: compounds 3, 1, 2 and 4 (each within the scatter of the next, the first and the last beyond it).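

In this assay, moving the fluorine alone, from 4-fluorobenzyl to 3-fluorobenzyl with the same atoms joined differently, gives a number 13 percentage points higher from compound 3 to compound 4 (beyond the scatter). The earlier steps all swapped the group on the sulfonyl sulfur and stayed within the scatter, so this is the first step among these compounds to go beyond it, which shows that the placing of the fluorine on the benzyl group can change the read-out, though this rests on one modest step between one pair of compounds. Nothing available here explains why this shift has that effect.

The compounds shown leave open whether 2-fluorobenzyl, 3-chlorobenzyl or plain benzyl would read differently from 3-fluorobenzyl. They also leave open whether the same change would give a similar step with 4-chlorophenyl or 2-nitrophenyl on the sulfonyl sulfur.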